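Exchanging the Aryl Group on the Shared Core

The source may report more compounds than this note shows. Statements on the series, on what has been measured and on what is new or still open speak of the compounds shown alone.

Compound 3 `Cc1nn(-c2nc(-c3ccc(Cl)c(Cl)c3)c(SC(C)C)s2)c(C(=O)O)c1-c1ccccc1Cl` gives 13100 nM in a functional assay on BJAB cells (Homo sapiens) for antiproliferative activity, with a stated time of 4 days (on this read-out higher numbers stand for an effect only at larger amounts of compound and lower numbers for an effect already at smaller amounts), and stands highest of the three measured compounds, while compound 1 `Cc1ccccc1-c1c(C)nn(-c2nc(-c3ccc(Cl)c(Cl)c3)c(SC(C)C)s2)c1C(=O)O` gives 5500 nM and compound 2 `COc1cc(C#N)cc(-c2c(C)nn(-c3nc(-c4ccc(Cl)c(Cl)c4)c(SC(C)C)s3)c2C(=O)O)c1` gives 5200 nM. Compound 4 `Cc1cccc(-c2c(C)nn(-c3nc(-c4ccc(Cl)c(Cl)c4)c(SC(C)C)s3)c2C(=O)O)c1` differs from compound 3 by 3-methylphenyl in place of 2-chlorophenyl on an aromatic carbon. Among the measured compounds shown here, two measured steps bear on this: a 2.4-fold higher number from compound 1 to compound 3 (0.38 log units; beyond the scatter) and a 2.5-fold higher number from compound 2 to compound 3 (0.40 log units; beyond the scatter). Since compound 4 again carries a methylphenyl group, as compound 1 does, a modestly lower number is expected because a 2.4-fold higher number from compound 1 to compound 3 (0.38 log units; beyond the scatter) ran the other way. Compound 4 is therefore estimated at 5500 nM, a step of a 2.4-fold lower number from compound 3 to compound 4 (0.38 log units; beyond the scatter), with a range from 2500 nM to 12000 nM.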

Compound 4, half-maximal effective concentration: 17000 nM
Compound 4: middle estimate off by 3.1-fold (0.49 log units), on the low side, outside the stated range (above it).
By their numbers in this assay, from the lowest: compounds 2 and 1 (each within the scatter of the next); then compounds 3 and 4 (each within the scatter of the next).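

In this assay the 3-methylphenyl group does not match the 2-methylphenyl group (a 3.1-fold higher number from compound 1 to compound 4 (0.49 log units; beyond the scatter)), so carrying a methylphenyl group at this position does not by itself fix the number. The 3-methylphenyl group instead matches 2-chlorophenyl (a 1.3-fold higher number from compound 3 to compound 4 (0.11 log units; within the scatter)) and differs from 3-cyano-5-methoxyphenyl (a 3.3-fold higher number from compound 2 to compound 4 (0.51 log units; beyond the scatter)), which places compounds 1 and 2 in one pair and compounds 3 and 4 in another. Nothing available explains this split. Still open, from the compounds shown here alone, is where 4-methylphenyl would fall, and whether a pyridine ring or an amine at this position would join either pair.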